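Mirror-image pairing of a glycine transporter inhibitor scaffold

A few compounds are considered here, and "the series" means these few. Any claim that something is new, unique, unknown or untested is made for them only; others in the source may bear on it.

Measured compounds:
compound 1 `CCCS(=O)(=O)[C@H]1CC[C@@](CNC(=O)c2ccc(Cl)cc2Cl)(CC2CC2)CC1`, 1630 nM
compound 2 `CCS(=O)(=O)[C@H]1CC[C@](CNC(=O)c2ccc(Cl)cc2Cl)(CC2CC2)CC1`, 132 nM

Of the compounds shown here, two have been measured in an assay on isolated protein for inhibition of sodium- and chloride-dependent glycine transporter 1 (Homo sapiens), with a stated time of 15 min; a lower number here means a stronger inhibitor, a higher number a weaker inhibitor. Compound 1 gives 1630 nM in this assay, whereas compound 2 gives 132 nM, the lower of the two numbers; the gap between them lies beyond the usual scatter. Compound 3 `CCS(=O)(=O)[C@H]1CC[C@@](CNC(=O)c2ccc(Cl)cc2Cl)(CC2CC2)CC1` has not yet been measured. It is related to compound 2 in this way: the two compounds have the same atoms and bonds and differ only in configuration as drawn: 2 of 2 stereo elements differ (all stereocentres are inverted: mirror images); a stereocentre at a saturated ring carbon is drawn s in compound 2 and r in compound 3; a stereocentre at a saturated ring carbon is drawn s in compound 2 and r in compound 3. Nothing in the measured pair shows directly how a change of configuration alone affects this assay, since compound 1 and compound 2 differ in more than one respect. The expectation for compound 3 is therefore uncertain, and a step of a 1.2-fold higher number from compound 2 to compound 3 (0.08 log units; within the scatter) of small size, well within the scatter, is taken as the central guess. On that basis compound 3 is estimated at 160 nM, with a plausible range from 50 nM to 600 nM.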

Compound 3, half-maximal inhibitory concentration: 1320 nM
Beside the measured number, compound 3's estimate is 8.3-fold (0.92 log units) below it, and the stated range ends below it.
By their numbers in this assay, from the lowest: compound 2; then compounds 3 and 1 (each within the scatter of the next).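

In this assay, configuration alone moves the number for this scaffold: inverting both stereocentres gives a 10-fold higher number from compound 2 to compound 3 (1.00 log units; beyond the scatter). This gap can be assigned to configuration and to nothing else for one reason: the fact that compounds 2 and 3 differ only in the configuration as drawn. Within the configuration of compound 3, the other change, hydrogen in place of methyl on a saturated chain carbon, two bonds along the chain from a sulfonyl sulfur, gives a 1.2-fold lower number from compound 1 to compound 3 (0.09 log units; within the scatter), so in this configuration that shortening from propyl to ethyl shows no effect beyond the scatter.

On these data alone, since both stereocentres invert together, the contribution of each one remains open. Also open, as far as these compounds go, are what the same chain change does in the configuration of compound 2, and whether a butyl chain on the sulfonyl, or an amine in place of the sulfonyl, would keep the same preference.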